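Selenocyanate carbamates: methyl on the phenyl ester ring

The source may hold more compounds than are shown below. What is called first, only, known or untested is meant among the compounds shown, and "the series" means these compounds.

Compound 1 `N#C[Se]c1ccc(NC(=O)Oc2ccccc2)cc1` is the phenyl carbamate of the series. In a functional assay on MCF7 cells (Homo sapiens) for cytotoxicity, read by MTT assay, with a stated time of 72 h (on this read-out lower numbers stand for higher toxicity in this test and higher numbers for lower toxicity in this test), compound 1 gives 67800 nM, the highest of the two numbers recorded so far; its nearest neighbour is compound 2 `CCCCCCOC(=O)Nc1ccc([Se]C#N)cc1`, which gives 63900 nM, and the pair sit within the scatter of each other. Within the data shown here, the single measured step, a 1.1-fold lower number from compound 1 to compound 2 (0.03 log units; within the scatter), exchanges the whole group on the carbonyl oxygen and changes the read-out by nothing that can be told from repeat error.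

Compound 3 `Cc1ccc(OC(=O)Nc2ccc([Se]C#N)cc2)cc1` keeps the phenyl ester of compound 1 and adds a substituent to it: methyl in place of hydrogen on an aromatic carbon, on an aromatic carbon of the phenyl ester ring. Among the measured compounds shown here, no measured step bears directly on this change. The step from compound 1 to compound 2 shows that a far larger alteration at the same end of the molecule left the read-out within the scatter, so a one-carbon addition is not expected to move it beyond the scatter in either direction; a step of a 1.0-fold lower number from compound 1 to compound 3 (0.02 log units; within the scatter) is estimated. Compound 3 is therefore expected to give about 65000 nM, with a range of 30000 nM to 140000 nM.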

Compound 3, concentration lethal to 50% of the cells: 69800 nM
Beside the measured number, compound 3's estimate is 1.1-fold (0.03 log units) below it; measured number inside the range.
By their numbers in this assay, from the lowest: compounds 2, 1 and 3 (each within the scatter of the next).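

In this assay the series now has its first reading on the phenyl ester ring itself: methyl in place of hydrogen on an aromatic carbon, para to a large group, gives a 1.0-fold higher number from compound 1 to compound 3 (0.01 log units; within the scatter), so adding this group to the ring leaves the read-out where it was. The earlier comparison, a 1.1-fold lower number from compound 1 to compound 2 (0.03 log units; within the scatter), exchanged the whole group on the carbonyl oxygen and said nothing about substitution on the ring, whereas this step shows that the ring can carry methyl at this place without a change that can be told from repeat error. No measurement of any property of these compounds accompanies the result, so this flat read-out stands without an explanation.

As far as these compounds go, all three compounds lie within the scatter of one another, so it remains open whether any change at this end of the molecule can move the number in this assay at all. An amine, a carboxylic acid or a trifluoromethyl group at the same place on the ring, or a chain longer than hexyl on the oxygen, would be the next tests of that question.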